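The source may report more compounds than this note shows. Statements on the series, on what has been measured and on what is new or still open speak of the compounds shown alone.

Three compounds that share one core have been run in an ADME assay on cells (Hepatocyte, Rattus norvegicus) for metabolic stability; a higher number here means faster removal of the compound, a lower number slower removal. Compound 1 `CCN(CC)CCN(C)c1ccc(Nc2cc(NC3CC3)n3ncc(C#N)c3n2)cc1NC(C)=O` gives 27 uL/min in this assay. Compound 3 `CC(=O)Nc1cccc(Nc2cc(NC3CC3)n3ncc(C#N)c3n2)c1` gives 26 uL/min in this assay, and the step from compound 1 to compound 3 is a 1.0-fold lower number from compound 1 to compound 3 (0.02 log units; within the scatter). Compound 2 `CC(=O)Nc1cc(Nc2cc(NC3CC3)n3ncc(C#N)c3n2)ccc1N1CCC[C@@H](N(C)C)C1` reaches only a limit of the assay in this assay, < 1 uL/min. Because of the limit of < 1 uL/min in this assay, at which 1 of the 3 values shown sits, the steps of an at least 27-fold lower number from compound 1 to compound 2 (1.43 log units; beyond the scatter) and an at least 26-fold higher number from compound 2 to compound 3 (1.41 log units; beyond the scatter) are themselves known only as limits, yet both are large, and compound 2 clearly stands apart from the other two.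

Compound 4 `CC(=O)Nc1cc(Nc2cc(NC3CC3)n3ncc(C#N)c3n2)ccc1N1CC[C@@H](N)C1` has not yet been measured in this assay. It differs from compound 2 in one place: a group of 6 heavy atoms (4 carbon, 2 nitrogen; one five-membered non-aromatic ring with 1 hetero atom) in place of a group of 9 heavy atoms (7 carbon, 2 nitrogen; one six-membered non-aromatic ring with 1 hetero atom), on an aromatic carbon. Both compound 2 and compound 4 carry an amine held within a ring at this aromatic carbon, whereas compound 1 carries an open chain there and compound 3 only a hydrogen. Among the compounds with values here, the steps that bear on the change are an at least 27-fold lower number from compound 1 to compound 2 (1.43 log units; beyond the scatter) and an at least 26-fold higher number from compound 2 to compound 3 (1.41 log units; beyond the scatter), which place the ring-bearing compound far from both of the others. The expected step is therefore small, an at least 2.0-fold higher number from compound 2 to compound 4 (0.30 log units; that floor lies within the scatter), and within the scatter. Compound 4 is estimated to give about 2 uL/min, with a range from 0.7 uL/min to 8 uL/min.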

Compound 4, intrinsic clearance in a liver preparation (reported as CLH), per the amount of preparation that the assay uses: 2.5 uL/min
Beside the measured number, compound 4's estimate is 1.3-fold (0.10 log units) below it, within the range that was stated.
By their numbers in this assay, from the lowest: compound 4; then compounds 3 and 1 (each within the scatter of the next). At a limit, below all of these: compound 2.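

Compound 4 gives a measured size to what compound 2 could show only as a limit in this assay: a 10-fold lower number from compound 3 to compound 4 (1.02 log units; beyond the scatter) and an 11-fold lower number from compound 1 to compound 4 (1.03 log units; beyond the scatter), so both compounds that hold an amine in a ring at this aromatic carbon sit low, while the open chain of compound 1 stays within the scatter of the hydrogen of compound 3. The low number also survives a real change in the ring, as 3-aminopyrrolidin-1-yl has a five-membered ring in place of a six-membered one and carries a hydrogen-bond donor that the leaving group lacks. Compound 2 sits at a limit of the assay, so an at least 2.5-fold higher number from compound 2 to compound 4 (0.39 log units; beyond the scatter) is only a floor and the true gap may be wider: the limit of < 1 uL/min in this assay, at which 1 of the 4 values shown sits.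

These compounds cannot say whether the ring or its amine goes with the low number, since the two always appear together here. A plain pyrrolidin-1-yl group with no amine, a morpholine ring, or an open chain ending in a primary amine at the same aromatic carbon would help to pull those two features apart.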